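Anilide series in LNCaP cytotoxicity: notes toward compound 4

The compounds below may be only part of what the source reports. "The series", "measured", "known", "first", "only" and "open" are said of these compounds alone.

compound 1 `COc1ccc(NC(=O)c2csc(-c3cn(Cc4ccc(Cl)cc4)c4ccccc34)n2)cc1` — > 100000 nM
compound 2 `COc1cc(NC(=O)c2csc(-c3c[nH]c4ccc(Br)cc34)n2)cc(OC)c1OC` — > 100000 nM
compound 3 `Cc1ccc(NC(=O)c2csc(-c3c[nH]c4ccccc34)n2)cc1` — > 100000 nM

All three values come from a functional assay on LNCaP cells (Homo sapiens) for cytotoxicity, read by MTT assay, with a stated time of 48 h, in the absence of a further agent; on this read-out higher numbers stand for weaker inhibition and lower numbers for stronger inhibition. Compound 1 stands only at a limit of this assay, the end of the measurable range rather than a number. Compound 2 likewise returns only a limit. The same is true of compound 3. Taken together, (the limit of > 100000 nM in this assay, at which 3 of the 3 values shown sit), and no measured step between any two of the three exists, so no size of a change can be read from the set so far.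

Compound 4 `COc1cc(NC(=O)c2csc(-c3cn(Cc4ccc(Cl)cc4)c4ccccc34)n2)cc(OC)c1OC` is not yet measured. It differs from compound 1 by 3,4,5-trimethoxyphenyl in place of 4-methoxyphenyl on an amide-type nitrogen. The group that enters is also carried by compound 2, and compound 2 sits at the same limit as compound 1, so nothing in the set points to that group bringing a value into the measurable range. The expected change a number no higher from compound 1 to compound 4 (the limit leaves the size open) is therefore none beyond the scatter. Compound 4 is accordingly estimated at 100000 nM, with a range from 30000 nM to 300000 nM, and most probably it too will reach only the limit of this assay.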

Compound 4, half-maximal inhibitory concentration: 97700 nM
Compound 4: the middle estimate sits 1.0-fold (0.01 log units) above what was measured; the range from low to high includes it.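

In this assay, for the compounds shown here, compound 4 gives 97700 nM, the first reading that is a number, so a compound with 3,4,5-trimethoxyphenyl on this amide-type nitrogen can return a value inside the measurable range. Compound 1 returns only > 100000 nM, which is a limit of the assay and not a number. The change therefore reads only as an at least 1.0-fold lower number from compound 1 to compound 4 (0.01 log units; that floor lies within the scatter), which leaves its true size open and gives no firm sign of a real shift, and the series as a whole still sits at the edge of the range: the limit of > 100000 nM in this assay, at which 3 of the 4 values shown sit.

On these data alone, whether an amine or a carboxylic acid in place of a methoxy group on the 3,4,5-trimethoxyphenyl would bring a value well inside the measurable range remains open. Also open, as far as these compounds go, is whether the reading of compound 4 would move with a single change elsewhere on the core of compound 4, such as a longer chain on the amide-type nitrogen's far side.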